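Isopropyl for isobutyl on a thiourea benzimidazole series

The source may report more compounds than this note shows. Statements on the series, on what has been measured and on what is new or still open speak of the compounds shown alone.

Compound 1 `CC(C)[C@H](NC(=S)NCc1ccccc1)c1nc2ccccc2[nH]1` and compound 2 `CC(C)C[C@H](NC(=S)NCc1ccccc1)c1nc2ccccc2[nH]1` share a core and differ in one place: isopropyl in place of isobutyl on a saturated chain carbon bound to an amide-type nitrogen and an aromatic carbon. In a functional assay on HeLa cells (Homo sapiens) for cytotoxicity, read by MTT assay (a lower number here means a stronger inhibitor, a higher number a weaker inhibitor), compound 2 gives 31200 nM and compound 1 gives 49900 nM; the step is a 1.6-fold higher number from compound 2 to compound 1 (0.20 log units; within the scatter). Compound 3 `CC(C)C[C@@H](NC(=S)Nc1cc(C(F)(F)F)cc(C(F)(F)F)c1)c1nc2ccccc2[nH]1` gives 10400 nM in this assay; how its core differs from that of compound 2 is not broken down here. Compound 4 `CC(C)[C@@H](NC(=S)Nc1cc(C(F)(F)F)cc(C(F)(F)F)c1)c1nc2ccccc2[nH]1` has not been measured. It differs from compound 3 by the same change: isopropyl in place of isobutyl on a saturated chain carbon bound to an amide-type nitrogen and an aromatic carbon, made on the core of compound 3. Since the earlier step of a 1.6-fold higher number from compound 2 to compound 1 (0.20 log units; within the scatter) stayed within the scatter, the step of a 1.4-fold higher number from compound 3 to compound 4 (0.16 log units; within the scatter) is expected to be of similar size. Compound 4 is estimated at 15000 nM in this assay, with a range of 7000 nM to 32000 nM.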

Compound 4, half-maximal inhibitory concentration: 16200 nM
Compound 4: middle estimate off by 1.1-fold (0.03 log units), on the low side, and the stated range covers the measured number.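

In this assay the new step is a 1.6-fold higher number from compound 3 to compound 4 (0.19 log units; within the scatter) and it agrees with the earlier step on the other core: the same change on two cores in this assay, a 1.6-fold higher number (0.20 log units; within the scatter) from compound 2 to compound 1 and a 1.6-fold higher number (0.19 log units; within the scatter) from compound 3 to compound 4, 1.0-fold (0.01 log units) apart, within the scatter of two such steps.
On these two cores, the change from isobutyl to isopropyl carries over at a similar size, with neither step beyond the scatter. Neither step shows that the change itself moves the number, and two cores give no rule for the wider series.

Open, as far as these compounds go, is whether a methyl group, a longer chain or a cyclohexyl group on the same carbon would give a step beyond the scatter. Also open, from the compounds shown here alone, is whether the step would hold on a core bearing an amine or a carboxylic acid.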